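A Fluorine on the Central Ring of Compound 1

The source may hold more compounds than are shown below. What is called first, only, known or untested is meant among the compounds shown, and "the series" means these compounds.

Compound 1 `COc1ccc(-c2cc(C(=O)Nc3ccc(Oc4ccnc5[nH]ccc45)cc3)ncn2)cc1` gives 4410 nM in a functional assay on A549 cells (Homo sapiens) for cytotoxicity, read by MTT assay, with a stated time of 72 h (a higher number here means a weaker inhibitor, a lower number a stronger inhibitor), the lowest of the three numbers shown, though the step of a 1.2-fold higher number from compound 1 to compound 3 (0.09 log units; within the scatter) is within the scatter. Compound 3 `Cc1ccc(-c2cc(C(=O)Nc3ccc(Oc4ccnc5[nH]ccc45)cc3)ncn2)cc1` gives 5410 nM in this assay, and compound 2 `O=C(Nc1ccc(Oc2ccnc3[nH]ccc23)cc1)c1cc(-c2ccc(F)cc2)ncn1` gives 13000 nM. The steps of a 2.9-fold higher number from compound 1 to compound 2 (0.47 log units; beyond the scatter) and a 2.4-fold lower number from compound 2 to compound 3 (0.38 log units; beyond the scatter) are modest. Compound 4 `COc1ccc(-c2cc(C(=O)Nc3ccc(Oc4ccnc5[nH]ccc45)c(F)c3)ncn2)cc1` differs from compound 1 by fluoro in place of hydrogen on an aromatic carbon. Among the measured compounds shown here, none of the measured steps touches this ring; all three exchange a group on the outer aryl ring, so no measured step bears directly on the change. Compound 4 is therefore expected to show a 1.0-fold lower number from compound 1 to compound 4 (0.00 log units; within the scatter), a step not expected to pass beyond the scatter. For compound 4 the estimate in this assay is 4400 nM, with a range from 1500 nM to 13000 nM.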

Compound 4, half-maximal inhibitory concentration: 4210 nM
The estimate for compound 4 lay 1.0-fold (0.02 log units) above the measured number, within the range that was stated.
By their numbers in this assay, from the lowest: compounds 4, 1 and 3 (each within the scatter of the next); then compound 2.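

Among the compounds shown here, compound 4 gives the first reading of a change on the ring that carries the fluoro, since the earlier steps all exchanged a group on the outer aryl ring. Fluoro in place of hydrogen at this place, ortho to a large group and meta to a large group, gives a 1.0-fold lower number from compound 1 to compound 4 (0.02 log units; within the scatter) in this assay, so one fluorine here leaves the number within the scatter. Nothing measured here offers a reason for this result.

On these data alone, whether an amine or a carboxylic acid at this place would leave the number equally undisturbed remains open. So does whether fluoro here would read the same alongside the outer aryl groups of compound 2 and compound 3.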